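The source may hold more compounds than are shown below. What is called first, only, known or untested is meant among the compounds shown, and "the series" means these compounds.

Measured compounds in a functional assay on HCT-116 cells (Homo sapiens) for inhibition, read by luminescence and resazurin assay, with a stated time of 3 days; on this read-out lower numbers stand for stronger inhibition and higher numbers for weaker inhibition:
compound 1 `O=S(=O)(Nc1ccc(CNc2nc(NC3CC3)nc3ccccc23)cc1)c1ccc(F)cc1`: 4900 nM
compound 2 `CNc1nc(NCc2ccc(NS(=O)(=O)c3ccc(F)cc3)cc2)c2ccccc2n1`: 5300 nM
compound 3 `CCCNc1nc(NCc2ccc(C(=O)NCc3ccc(F)cc3)cc2)c2cc(C)ccc2n1`: 4400 nM

Compound 2 gives the highest of the three numbers, but its gap to compound 1 and its gap to compound 3 both lie within the scatter, so no order can be read among these three. For the measured compounds named here, the only one-place step among the measured compounds is a 1.1-fold higher number from compound 1 to compound 2 (0.03 log units; within the scatter), which leaves the read-out unchanged beyond the scatter.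

Compound 4 `CNc1nc(NCc2ccc(NC(=O)c3ccc(F)cc3)cc2)c2ccccc2n1` differs from compound 2 in one place: (4-fluorophenyl)carbonyl in place of (4-fluorophenyl)sulfonyl on a nitrogen on an aromatic ring. Going by the values given here, no measured step touches this change. Compound 3, which contains an amide rather than a sulfonamide, differs from compound 2 in more than one place and cannot be used as a step; compound 3 gives 4400 nM, within the scatter of compound 2. Nothing in the set therefore points in either direction for the exchange of the sulfonyl group for the carbonyl group.

Among the compounds with values here, with no measured step bearing on it, the step expected in this assay is a 1.1-fold lower number from compound 2 to compound 4 (0.03 log units; within the scatter), none beyond the scatter. Within the data shown here, the estimate for compound 4 is accordingly 5000 nM, with a range of 1800 nM to 14000 nM; the range is kept wide because no measured step covers this change.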

Compound 4, half-maximal inhibitory concentration: 1600 nM
The estimate for compound 4 lay 3.1-fold (0.49 log units) above the measured number; the whole stated range lies above it.
By their numbers in this assay, from the lowest: compound 4; then compounds 3, 1 and 2 (each within the scatter of the next).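

In this assay, (4-fluorophenyl)carbonyl in place of (4-fluorophenyl)sulfonyl on a nitrogen on an aromatic ring gives a 3.3-fold lower number from compound 2 to compound 4 (0.52 log units; beyond the scatter) and so shows that the read-out responds to a change at this place, unlike the step of methyl in place of cyclopropyl, which stayed within the scatter. The step is modest and rests on this single pair, so it describes the exchange only on the core shared by compound 2 and compound 4, and no general preference for carbonyl over sulfonyl can be claimed from it. The data at hand offer no measurement that accounts for the difference between the two groups, and no cause can be assigned to it.

From the compounds shown here alone, whether the same exchange gives a step of similar size with cyclopropyl in place of methyl, as in compound 1, remains open. Also open, going by these compounds, is how the read-out would respond to a urea at this place, or to a carboxylic acid or a dimethylamino group in place of the fluorine on the aromatic ring of the (4-fluorophenyl)carbonyl group.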